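Aryl swap on the ring nitrogen: compound 2 to compound 3

The source may report more compounds than this note shows. Statements on the series, on what has been measured and on what is new or still open speak of the compounds shown alone.

Compound 1 `CNC(=O)c1cc(Oc2ccc(NC(=O)c3nn(-c4cccc(F)c4)c(=O)cc3C)cc2F)ccn1` gives 6410 nM in a functional assay on MCF7 cells (Homo sapiens) for cytotoxicity, read by MTT assay, with a stated time of 72 h; a higher number here means a weaker inhibitor, a lower number a stronger inhibitor.
Compound 2 `Cc1cc(=O)n(-c2ccccc2OC(F)(F)F)nc1C(=O)Nc1ccc(Oc2ncnc3ccsc23)c(F)c1` gives 11500 nM in this assay.

Only these two numbers are known, and compound 2 lies within the usual scatter of compound 1, so the pair shows no readable difference. Compound 3 `Cc1cc(=O)n(-c2cccc(F)c2)nc1C(=O)Nc1ccc(Oc2ncnc3ccsc23)c(F)c1` carries the change (3-fluorophenyl in place of 2-(trifluoromethoxy)phenyl on an aromatic nitrogen). Going by the values given here, no step between measured compounds isolates this change. Compound 1 holds the same 3-fluorophenyl on a different core and gives 6410 nM. On that basis the step of a 1.6-fold lower number from compound 2 to compound 3 (0.22 log units; within the scatter) is expected to stay within the scatter, leaning toward a lower number. Compound 3 is estimated at 7000 nM, with a range of 2500 nM to 20000 nM.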

Compound 3, half-maximal inhibitory concentration: 9050 nM
Beside the measured number, compound 3's estimate is 1.3-fold (0.11 log units) below it, and the stated range covers the measured number.
By their numbers in this assay, from the lowest: compounds 1, 3 and 2 (each within the scatter of the next).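

The swap of 2-(trifluoromethoxy)phenyl for 3-fluorophenyl on the aromatic nitrogen comes to a 1.3-fold lower number from compound 2 to compound 3 (0.10 log units; within the scatter) in this assay, so these two aryl groups are not told apart at this position. With 3-fluorophenyl held fixed, the exchange of the group on the oxygen comes to a 1.4-fold higher number from compound 1 to compound 3 (0.15 log units; within the scatter) and likewise leaves no readable difference. Nothing available gives a reason for either result. Going by these compounds, whether a phenyl bearing an amine or a carboxylic acid on that nitrogen would move the number beyond the scatter stays open.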